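Nitro for chloro at the cytotoxicity limit

This account rests on a few compounds, and the source may have more. Where it says the series, first, only, none or still open, it means among the compounds named here.

Measured in an ADME assay on Vero cells (Chlorocebus sabaeus) for cytotoxicity, read by WST assay; a higher number here means that more compound is tolerated, a lower number that less compound is tolerated:
- compound 1 `O=c1[nH]c(Nc2ccc(F)cc2F)nc2cc(Cl)ccc12`: > 25000 nM
- compound 2 `O=c1[nH]c(Nc2cc(Cl)cc(Cl)c2)nc2cc(Cl)ccc12`: > 25000 nM

Neither entry is a number, and both are limits of the assay. Compound 2 stands at > 25000 nM, which is a limit. It shares that position with compound 1, and the whole picture so far is the limit of > 25000 nM in this assay, at which 2 of the 2 values shown sit. For the measured compounds named here, no step between measured compounds can therefore be read from these data.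

Compound 3 `O=c1[nH]c(Nc2cc(Cl)cc(Cl)c2)nc2cc([N+](=O)[O-])ccc12` has not yet been measured. It differs from compound 2 by nitro in place of chloro on an aromatic carbon. Nothing measured shows what this exchange does in this assay, so the expectation rests on the limit of compound 2, > 25000 nM. No change beyond the scatter is expected, and the estimated step is a number no higher from compound 2 to compound 3 (the limit leaves the size open). A lower reading would still not be a surprise, and another limit is quite likely. Compound 3 is estimated at 25000 nM, with an expected range of 9000 nM to 50000 nM.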

Compound 3, half-maximal cytotoxic concentration: > 25000 nM
Compound 3 ended at the assay's limit; the forecaster's own chance of this, stated with the estimate: 65%; the middle value lies on the limit itself.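

In this assay compound 3 gives > 25000 nM as a limit of the assay. Compound 2 gives > 25000 nM as a limit too. For the compounds shown here, no step between compound 2 and compound 3 can be read, and the picture remains a single one: the limit of > 25000 nM in this assay, at which 3 of the 3 values shown sit. The compounds shown leave open what nitro in place of chloro on an aromatic carbon does to the tolerated concentration.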